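Notes on the step from compound 3 to compound 4

The source may hold more compounds than are shown below. What is called first, only, known or untested is meant among the compounds shown, and "the series" means these compounds.

- compound 1 `COc1cc(N2CCC(C(=O)N3CCC(N(C)C)C3)CC2)ccc1Nc1nc(NC2CCCCC2)c2nc[nH]c2n1`: 58 nM
- compound 2 `CCN(CC)CC1CCN(c2ccc(Nc3nc(NC4CCCCC4)c4nc[nH]c4n3)c(OC)c2)CC1`: 74 nM
- compound 3 `COc1cc(N2CCC(CC(=O)N3CCCC3)CC2)ccc1Nc1nc(NC2CCCCC2)c2nc[nH]c2n1`: 15 nM

In a functional assay on HCT-116 cells (Homo sapiens) for cytotoxicity (on this read-out higher numbers stand for weaker inhibition and lower numbers for stronger inhibition), compound 3 has the lowest number of the three. Compound 4 `COc1cc(N2CCC(C(=O)N3CC(O)C3)CC2)ccc1Nc1nc(NC2CCCCC2)c2nc[nH]c2n1` departs from it at one place: (3-hydroxyazetidin-1-yl)carbonyl in place of ((pyrrolidin-1-yl)carbonyl)methyl on a saturated ring carbon. This puts (3-hydroxyazetidin-1-yl)carbonyl in place of ((pyrrolidin-1-yl)carbonyl)methyl on a saturated ring carbon.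

Within the data shown here, no measured compound carries the entering group. Among the measured compounds shown here, the closest precedent is compound 1, which also has a carbonyl-linked group on that ring carbon, and the measured change from it is a 3.9-fold lower number from compound 1 to compound 3 (0.59 log units; beyond the scatter). Read in reverse, that step suggests a modest rise. The change a 4.9-fold lower number from compound 2 to compound 3 (0.69 log units; beyond the scatter) is of similar size, but compound 2 has no carbonyl in that group, so it bears less directly. The change a 1.3-fold higher number from compound 1 to compound 2 (0.11 log units; within the scatter) adds little. For the measured compounds named here, with only three measured compounds, the expectation is a loose one.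

The expected change is a 2.7-fold higher number from compound 3 to compound 4 (0.43 log units; beyond the scatter). For compound 4 the estimated value is 40 nM, with an expected range from 13 nM to 120 nM.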

Compound 4, half-maximal inhibitory concentration: 50 nM
Compound 4: middle estimate off by 1.3-fold (0.10 log units), on the low side, within the range that was stated.
By their numbers in this assay, from the lowest: compound 3; then compounds 4, 1 and 2 (each within the scatter of the next).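

In this assay the exchange of ((pyrrolidin-1-yl)carbonyl)methyl for (3-hydroxyazetidin-1-yl)carbonyl on this saturated ring carbon gives a 3.3-fold higher number from compound 3 to compound 4 (0.52 log units; beyond the scatter) and so does not keep the standing of compound 3. The other two comparisons show a 1.5-fold lower number from compound 2 to compound 4 (0.17 log units; within the scatter) and a 1.2-fold lower number from compound 1 to compound 4 (0.06 log units; within the scatter) and leave compound 4 level with both, so among the four compounds only compound 3 stands apart. On the carbonyl carbon, 3-hydroxyazetidin-1-yl and 3-(dimethylamino)pyrrolidin-1-yl do not separate beyond the scatter.

The step from compound 3 changes the chain carbon and the amide ring together, so a (pyrrolidin-1-yl)carbonyl group set directly on the ring carbon would be needed to tell these two parts apart. The data shown offer no explanation for the gap to compound 3.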